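The source may report more compounds than this note shows. Statements on the series, on what has been measured and on what is new or still open speak of the compounds shown alone.

Compound 1 `CN1CCN(c2ccc(Nc3ncc4nc(Nc5ccc(F)cc5)n([C@@H]5CCN(C(=O)CO)C5)c4n3)cc2)CC1` carries a five-membered ring on the aromatic nitrogen of the shared core; in a functional assay on A549 cells (Homo sapiens) for antiproliferative activity, read by MTT assay, with a stated time of 72 h (a lower number here means a stronger inhibitor, a higher number a weaker inhibitor), compound 1 has "not determined" (no result reported), so no number is available for it. Compound 2 `CN1CCN(c2ccc(Nc3ncc4nc(Nc5ccc(F)cc5)n([C@H]5CCCN(S(=O)(=O)C6CC6)C5)c4n3)cc2)CC1` gives 1320 nM in this assay, and compound 3 `CN1CCN(c2ccc(Nc3ncc4nc(Nc5ccc(F)cc5)n([C@H]5CCCN(C(=O)CO)C5)c4n3)cc2)CC1` gives 830 nM. Among the compounds with values here, the single measured step, a 1.6-fold lower number from compound 2 to compound 3 (0.20 log units; within the scatter), exchanges one substituent on the amine nitrogen of the six-membered ring. Compound 3 thus stands with the lower of the two numbers, but its gap to compound 2 lies within the scatter, so the two cannot be told apart.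

Compound 4 `CN1CCN(c2ccc(Nc3ncc4nc(Nc5ccc(F)cc5)n(-c5cccc(NC(=O)CO)c5)c4n3)cc2)CC1` is not yet measured. It differs from compound 3 by 3-(((hydroxymethyl)carbonyl)amino)phenyl in place of 1-((hydroxymethyl)carbonyl)piperidin-3-yl on an aromatic nitrogen, the change sitting on an aromatic nitrogen of a five-membered aromatic ring with two nitrogens, part of a fused system of two rings. Within the data shown here, no measured step touches this ring; the step from compound 2 to compound 3 alters only the group on the amine nitrogen and therefore bears little on it. Among the measured compounds shown here, with no step to guide the direction, compound 4 is expected to land near compound 3, with the step of a 1.8-fold higher number from compound 3 to compound 4 (0.26 log units; within the scatter) estimated as no change beyond the scatter, and a wide range is attached. Compound 4 is estimated at 1500 nM, between 400 nM and 6000 nM.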

Compound 4, half-maximal inhibitory concentration: 1510 nM
The estimate for compound 4 lay 1.0-fold (0.00 log units) below the measured number, and the stated range covers the measured number.
By their numbers in this assay, from the lowest: compounds 3, 2 and 4 (each within the scatter of the next).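

Within the data shown here, this is the first measured change on the aromatic nitrogen of the shared core. In this assay, putting 3-(((hydroxymethyl)carbonyl)amino)phenyl in place of 1-((hydroxymethyl)carbonyl)piperidin-3-yl gives a 1.8-fold higher number from compound 3 to compound 4 (0.26 log units; within the scatter) and the step against 1-(cyclopropylsulfonyl)piperidin-3-yl gives a 1.1-fold higher number from compound 2 to compound 4 (0.06 log units; within the scatter) so neither step separates the six-membered non-aromatic ring, with its defined stereocentre, from the six-membered aromatic ring of carbon only. With both steps inside the scatter, compound 2, compound 3 and compound 4 cannot be told apart in this read-out, and no evidence beyond these numbers bears on the result.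

The compounds shown leave open whether any group on this aromatic nitrogen can move the number beyond the scatter, since every step so far stays within it. An open alkyl chain in place of the ring, or an amine or a carboxylic acid in place of the hydroxymethyl carbonyl group on the phenyl ring, would test this, and the direction of any such change cannot be read from these compounds.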